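A few compounds are considered here, and "the series" means these few. Any claim that something is new, unique, unknown or untested is made for them only; others in the source may bear on it.

Series notes, shared core of compound 1 `CCN(CC)c1ccc2cc(C(=O)c3ccc(N4CCN(C(=O)CN5CCNCC5)CC4)cc3)oc2c1`. In a functional assay on SGC-7901 cells (Homo sapiens) for cytotoxicity, read by MTT assay, with a stated time of 48 h (a higher number here means a weaker inhibitor, a lower number a stronger inhibitor), compound 1 gives 1220 nM. Compound 2 `CCN(CC)c1ccc2cc(C(=O)c3ccc(N4CCN(C(=O)CN5CCN(S(=O)(=O)C6CC6)CC5)CC4)cc3)oc2c1` gives 15300 nM, and compound 3 `CCN(CC)c1ccc2cc(C(=O)c3ccc(N4CCN(C(=O)CN5CCN(Cc6ccc(C(F)(F)F)cc6)CC5)CC4)cc3)oc2c1` gives 32000 nM. Compound 3 stands highest of the three, compound 2 nearest and compound 1 furthest: the steps of a 2.1-fold higher number from compound 2 to compound 3 (0.32 log units; beyond the scatter) and a 26-fold higher number from compound 1 to compound 3 (1.42 log units; beyond the scatter) both run beyond the scatter, as does a 13-fold higher number from compound 1 to compound 2 (1.10 log units; beyond the scatter). Compound 4 `CCN(CC)c1ccc2cc(C(=O)c3ccc(N4CCN(C(=O)CN5CCN(CC(C)=O)CC5)CC4)cc3)oc2c1` is not yet measured. Against compound 3 the change is acetyl in place of 4-(trifluoromethyl)phenyl on a saturated chain carbon bound to an amine nitrogen in a ring. Within the data shown here, the steps that bear on it are those placing a group on the amine nitrogen in a ring: a 13-fold higher number from compound 1 to compound 2 (1.10 log units; beyond the scatter) and a 26-fold higher number from compound 1 to compound 3 (1.42 log units; beyond the scatter) were both large, a 2.1-fold higher number from compound 2 to compound 3 (0.32 log units; beyond the scatter) modest, so each substituted ring nitrogen has read higher than the unsubstituted one. Compound 4 keeps a substituent on that nitrogen, so its number is expected to remain far above that of compound 1. For compound 4 the expected step is a 2.1-fold lower number from compound 3 to compound 4 (0.33 log units; beyond the scatter), modest and in no secure direction. The estimate for compound 4 is 15000 nM, range 5000 nM to 45000 nM.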

Compound 4, half-maximal inhibitory concentration: 2210 nM
Beside the measured number, compound 4's estimate is 6.8-fold (0.83 log units) above it; the measured number lies below the stated range.
By their numbers in this assay, from the lowest: compounds 1 and 4 (each within the scatter of the next); then compound 2; then compound 3.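

In this assay, a substituent on the amine nitrogen in a ring does not by itself carry the number up: 2-oxopropyl gives a 1.8-fold higher number from compound 1 to compound 4 (0.26 log units; within the scatter) and so stands apart from the reading drawn from compound 2 and compound 3. What matters is the group itself, since a 6.9-fold lower number from compound 2 to compound 4 (0.84 log units; beyond the scatter) comes with 2-oxopropyl in place of cyclopropylsulfonyl, and a 14-fold lower number from compound 3 to compound 4 (1.16 log units; beyond the scatter) comes with acetyl in place of 4-(trifluoromethyl)phenyl on the saturated chain carbon. Nothing at hand explains these steps.

Still open, from the compounds shown here alone, is whether the carbonyl of the acetyl counts, or only the loss of the 4-(trifluoromethyl)phenyl ring. A plain benzyl, a propyl or a 2-hydroxypropyl on the same nitrogen would separate those two readings.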